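The compounds below may be only part of what the source reports. "The series", "measured", "known", "first", "only" and "open" are said of these compounds alone.

Measured compounds in a functional assay on A549 cells (Homo sapiens) for cytotoxicity, read by MTT assay, with a stated time of 4 days; on this read-out higher numbers stand for weaker inhibition and lower numbers for stronger inhibition:
Compound 1 `Cc1ccc(S(=O)(=O)Oc2ccc3c(c2C)[C@H](Cn2cc(-c4ccccn4)nn2)[C@@]24CC(=O)[C@@](C)(CC[C@@H]32)C4)cc1` gives > 20000 nM, a limit of the assay.
Compound 2 `C=C1C(=O)[C@]23C[C@@]1(O)CC[C@H]2c1ccc(O)c(C)c1[C@@H]3Cn1cc(-c2ccccn2)nn1` gives 1570 nM.
Compound 3 `Cc1c(O)ccc2c1[C@H](Cn1cc(-c3ccccn3)nn1)[C@@]13CC(=O)[C@@](C)(CC[C@@H]21)C3` gives > 20000 nM, a limit of the assay.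

Compound 1 stands at the limit of this assay. Compound 3 sits at the same limit, as the limit of > 20000 nM in this assay, at which 2 of the 3 values shown sit, records; only compound 2 gives a number. For the measured compounds named here, the one step measured from compound 1 is a step that the two limits leave unreadable from compound 1 to compound 3, which the two limits leave unreadable. Compound 4 `Cc1ccc(S(=O)(=O)Oc2ccc3c(c2C)[C@H](Cn2cc(-c4ccc(Br)cc4)nn2)[C@@]24CC(=O)[C@@](C)(CC[C@@H]32)C4)cc1` differs from compound 1 by 4-bromophenyl in place of pyridin-2-yl on an aromatic carbon. Going by the values given here, no measured pair shows this change, and the single step from compound 1 cannot be read, so no direction beyond the scatter follows in this assay. Compound 4 is therefore expected to remain near the limit, estimated at 25000 nM with a range of 8000 nM to 80000 nM. The step this estimate implies is a step that the limit leaves unreadable from compound 1 to compound 4.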

Compound 4, half-maximal inhibitory concentration: > 20000 nM
Compound 4: only a limit was reported; the forecaster's own chance of this, stated with the estimate: 70%; the middle value lies beyond the limit too.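

Compound 1 and compound 4 both sit at the limit of the assay, so no new step can be read between them: the limit of > 20000 nM in this assay, at which 3 of the 4 values shown sit.

Open remains whether 4-bromophenyl in place of pyridin-2-yl shifts the read-out at all, and in which direction.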